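A few compounds are considered here, and "the series" means these few. Any claim that something is new, unique, unknown or untested is made for them only; others in the source may bear on it.

In a functional assay on A549 cells (Homo sapiens) for antiproliferative activity, read by MTT assay, with a stated time of 72 h (a higher number here means a weaker inhibitor, a lower number a stronger inhibitor), three compounds sharing one core have been measured: compound 1 `COc1ccccc1-c1ccc2ncn(-c3cc(OC)c(OC)c(OC)c3)c2c1` gives 4320 nM, compound 2 `COc1cc(-n2cnc3ccc(-c4ccc(C(C)=O)cc4)cc32)cc(OC)c1OC` gives 2510 nM, and compound 3 `COc1cc(-n2cnc3ccc(-c4cc(F)ccc4F)cc32)cc(OC)c1OC` gives 7940 nM. Compound 3 stands close to one neighbour and apart from the other: a 1.8-fold higher number from compound 1 to compound 3 (0.26 log units; within the scatter) lies within the scatter, while a 3.2-fold higher number from compound 2 to compound 3 (0.50 log units; beyond the scatter) goes beyond it. Compound 4 `COc1cc(-n2cnc3ccc(-c4cccc(O)c4)cc32)cc(OC)c1OC` carries 3-hydroxyphenyl in place of 2,5-difluorophenyl on an aromatic carbon. Swaps at this place have so far moved the number little, with a 1.7-fold lower number from compound 1 to compound 2 (0.24 log units; within the scatter) within the scatter and a 3.2-fold higher number from compound 2 to compound 3 (0.50 log units; beyond the scatter) only modest. A small shift toward the values of the other two compounds is therefore expected, not a large one. The expected step is a 1.8-fold lower number from compound 3 to compound 4 (0.25 log units; within the scatter). For compound 4 the estimated value is 4500 nM, with an expected range of 1400 nM to 13000 nM.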

Compound 4, half-maximal inhibitory concentration: 250 nM
Beside the measured number, compound 4's estimate is 18-fold (1.26 log units) above it; measured number below the stated range.
By their numbers in this assay, from the lowest: compound 4; then compounds 2, 1 and 3 (each within the scatter of the next, the first and the last beyond it).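

In this assay this position proves far more sensitive than the earlier swaps suggested: 3-hydroxyphenyl gives a 32-fold lower number from compound 3 to compound 4 (1.50 log units; beyond the scatter) and also separates from the other two groups, with a 10-fold lower number from compound 2 to compound 4 (1.00 log units; beyond the scatter) and a 17-fold lower number from compound 1 to compound 4 (1.24 log units; beyond the scatter) as well. Of the groups shown here, only 3-hydroxyphenyl carries a hydrogen-bond donor, and it is also the only one that stands clearly apart from the rest. No evidence is available to explain this gain.

Going by these compounds, whether the hydroxyl itself matters remains open, and a 3-aminophenyl or 3-methoxyphenyl group would test this. A 4-hydroxyphenyl group would show whether its place on the ring counts.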